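The source may hold more compounds than are shown below. What is called first, only, known or untested is meant among the compounds shown, and "the series" means these compounds.

Measured so far in a functional assay on VCaP cells (Homo sapiens) for antiproliferative activity, read by CCK-8 assay, with a stated time of 6 days; a lower number here means a stronger inhibitor, a higher number a weaker inhibitor:
compound 1 `N#Cc1ccc(N2CCCc3c(-c4cccnc4)cccc32)cc1C(F)(F)F` gives 13500 nM
compound 2 `CCN(c1ccc(C#N)c(Cl)c1)c1cc(-c2cn[nH]c2)ccc1C` has no reported result, "not determined" (no result reported)
compound 3 `CCN(c1cccc(-n2ccnc2)c1)c1ccc(C#N)c(C(F)(F)F)c1` is reported only as a limit, > 30000 nM

Among the compounds with values here, compound 1 supplies the only numerical value in this assay. For compound 3 the assay reports a limit and no number, (the limit of > 30000 nM in this assay, at which 1 of the 3 values shown sits). Compound 2 stands without any result. Compound 4 `Cn1nccc1-c1cccc2c1CCCN2c1ccc(C#N)c(C(F)(F)F)c1` differs from compound 1 in one place: 1-methyl-1H-pyrazol-5-yl in place of pyridin-3-yl on an aromatic carbon. Within the data shown here, no measured pair differing in one place exists here, so the size of this step is not anchored by any measured comparison. The step from compound 1 to compound 4 is expected to be small, within or only slightly beyond the scatter, a 1.4-fold lower number from compound 1 to compound 4 (0.13 log units; within the scatter). Compound 4 is therefore estimated at 10000 nM, within 2000 nM to 30000 nM.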

Compound 4, half-maximal inhibitory concentration: > 30000 nM
Compound 4 ended at the assay's limit (the forecaster's own chance of this, stated with the estimate: 25%); middle value at least 3.0-fold (0.47 log units) from the limit.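

In this assay, this aromatic carbon of the shared core now has its first measured step: 1-methyl-1H-pyrazol-5-yl in place of pyridin-3-yl gives an at least 2.2-fold higher number from compound 1 to compound 4 (0.34 log units; beyond the scatter). For these two compounds, replacing the six-membered aromatic ring with a five-membered one therefore changes the result beyond the scatter. The reading for compound 4 is a limit and not a number, so the step has only a minimum size: the limit of > 30000 nM in this assay, at which 2 of the 4 values shown sit.

As far as these compounds go, it remains open how an amine, a carboxylic acid or a longer alkyl chain on this carbon would read. From the compounds shown here alone, it also remains open whether any group here gives a lower number than compound 1.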